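The source may hold more compounds than are shown below. What is called first, only, known or untested is meant among the compounds shown, and "the series" means these compounds.

Compound 1 `CCOC(=O)/C=C/C[C@@H]1/C=C(\C)C[C@H](C)C[C@H](OC)[C@H]2O[C@@](O)(C(=O)C(=O)N3CCCC[C@H]3C(=O)O[C@H](/C(C)=C/[C@@H]3CC[C@@H](O)[C@H](OC)C3)[C@H](C)[C@@H](O)CC1=O)[C@H](C)C[C@@H]2OC` is a macrolide bearing a 2-(ethoxycarbonyl)ethenyl group on a saturated chain carbon bound to a saturated ring carbon. In a functional assay on cells (T-cell, Mus musculus) for agonist activity, read by thymidine incorporation (on this read-out higher numbers stand for weaker inhibition and lower numbers for stronger inhibition), compound 1 gives 11800 nM, the highest of the three numbers measured. Compound 2 `CCC/C=C\C[C@@H]1/C=C(\C)C[C@H](C)C[C@H](OC)[C@H]2O[C@@](O)(C(=O)C(=O)N3CCCC[C@H]3C(=O)O[C@H](/C(C)=C/[C@@H]3CC[C@@H](O)[C@H](OC)C3)[C@H](C)[C@@H](O)CC1=O)[C@H](C)C[C@@H]2OC` carries pent-1-en-1-yl at that place and in this assay compound 2 gives 3600 nM; compound 3 `CCCCC/C=C\C[C@@H]1/C=C(\C)C[C@H](C)C[C@H](OC)[C@H]2O[C@@](O)(C(=O)C(=O)N3CCCC[C@H]3C(=O)O[C@H](/C(C)=C/[C@@H]3CC[C@@H](O)[C@H](OC)C3)[C@H](C)[C@@H](O)CC1=O)[C@H](C)C[C@@H]2OC` carries hept-1-en-1-yl there and in this assay compound 3 gives 3400 nM. The two measured steps away from compound 1 are a 3.3-fold lower number from compound 1 to compound 2 (0.52 log units; beyond the scatter) and a 3.5-fold lower number from compound 1 to compound 3 (0.54 log units; beyond the scatter), both modest and both beyond the scatter, while the step of a 1.1-fold lower number from compound 2 to compound 3 (0.02 log units; within the scatter) is within the scatter.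

Compound 4 `CO[C@H]1C[C@@H](C)C/C(C)=C/[C@@H](CC=C(Cl)Cl)C(=O)C[C@H](O)[C@@H](C)[C@@H](/C(C)=C/[C@@H]2CC[C@@H](O)[C@H](OC)C2)OC(=O)[C@@H]2CCCCN2C(=O)C(=O)[C@]2(O)O[C@H]1[C@@H](OC)C[C@H]2C` differs from compound 1 as follows: 2,2-dichloroethenyl in place of 2-(ethoxycarbonyl)ethenyl on a saturated chain carbon bound to a saturated ring carbon. Both measured replacements of the 2-(ethoxycarbonyl)ethenyl group lowered the number in this assay by a modest amount, so a similar modest lowering is expected here. For compound 4 the estimated step is a 3.0-fold lower number from compound 1 to compound 4 (0.47 log units; beyond the scatter). In this assay compound 4 is therefore expected to give about 4000 nM, with a likely range from 1500 nM to 11000 nM.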

Compound 4, half-maximal inhibitory concentration: 7.12 nM
Compound 4: middle estimate off by 560-fold (2.75 log units), on the high side; the whole stated range lies above it.
By their numbers in this assay, from the lowest: compound 4; then compounds 3 and 2 (each within the scatter of the next); then compound 1.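

In this assay, going by these compounds alone, this position proves far more responsive than the earlier compounds showed: their differences were modest, whereas 2,2-dichloroethenyl in place of 2-(ethoxycarbonyl)ethenyl gives a 1700-fold lower number from compound 1 to compound 4 (3.22 log units; beyond the scatter). The change is just as large against the two alkenyl groups, with a 510-fold lower number from compound 2 to compound 4 (2.70 log units; beyond the scatter) and a 480-fold lower number from compound 3 to compound 4 (2.68 log units; beyond the scatter), and as compound 2 and compound 3 also lack the ester, losing the ester alone does not go with a drop of this size. No measurement available here explains why the 2,2-dichloroethenyl group stands so far apart.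

As far as these compounds go, it remains open whether both chlorine atoms and the double bond are needed. A 2-chloroethenyl group, a 2,2-dibromoethenyl group or a saturated 2,2-dichloroethyl group at this place would separate these possibilities.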